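Two Substitutions Around a Shared Core

A few compounds are considered here, and "the series" means these few. Any claim that something is new, unique, unknown or untested is made for them only; others in the source may bear on it.

Compound 1 `O=C1c2ccc(C#Cc3ccccc3)nc2CCN1C1CCCC1`: 890 nM
Compound 2 `Cc1ccc(C#Cc2ccc3c(n2)CCN(C2CCCC2)C3=O)cc1`: > 32000 nM
Compound 3 `O=C1c2ccc(C#Cc3ccccc3)nc2CCN1C1CCCCC1`: 12400 nM

In an assay on HEK293 cells for displacement of a labelled ligand from metabotropic glutamate receptor 5 (Homo sapiens), with a stated time of 2 h (a lower number here means a stronger inhibitor, a higher number a weaker inhibitor), compound 1 gives 890 nM. For compound 2 the assay reports only a limit, > 32000 nM. Compound 3 gives 12400 nM, the higher of the two numbers, with compound 1 the nearest. The change from compound 1 to compound 2 is methyl in place of hydrogen on an aromatic carbon, and it made an at least 35-fold higher number from compound 1 to compound 2 (1.55 log units; beyond the scatter). The change from compound 1 to compound 3 is cyclohexyl in place of cyclopentyl on an amide-type nitrogen in a ring, which made a 14-fold higher number from compound 1 to compound 3 (1.14 log units; beyond the scatter).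

Compound 4 `Cc1ccccc1C#Cc1ccc2c(n1)CCN(C1CCCCC1)C2=O` has not yet been measured. It differs from compound 3 by methyl in place of hydrogen on an aromatic carbon, the same kind of change as that from compound 1 to compound 2, but placed differently: there the methyl sits para to a large group, here ortho to a large group. Compound 4 is expected to show a further large loss in this assay, a step of about a 4.8-fold higher number from compound 3 to compound 4 (0.68 log units; beyond the scatter), resting on the step of an at least 35-fold higher number from compound 1 to compound 2 (1.55 log units; beyond the scatter). Compound 4 is estimated at 60000 nM, between 15000 nM and 250000 nM, with a fair chance that only a limit is reported.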

Compound 4, inhibition constant: > 32000 nM
Compound 4: no number, only a limit (the forecaster's own chance of this, stated with the estimate: 70%); the middle value is on the limit's open side.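

Carried from the cyclopentyl core to the cyclohexyl core, methyl in place of hydrogen again gives a weaker result in this assay, with an at least 2.5-fold higher number from compound 3 to compound 4 (0.41 log units; beyond the scatter), so the direction of the change holds in both pairs: the same change on two cores in this assay, an at least 35-fold higher number (1.55 log units; beyond the scatter) from compound 1 to compound 2 and an at least 2.5-fold higher number (0.41 log units; beyond the scatter) from compound 3 to compound 4; the limit leaves it open whether they differ. Compound 4 is reported only as a limit, > 32000 nM. Going by these compounds, the size of the step on the cyclohexyl core therefore stays unknown, and the methyl, ortho to a large group in compound 4, stands at a different place in compound 2, so this is no clean test of transfer: the limit of > 32000 nM in this assay, at which 2 of the 4 values shown sit.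

The compounds shown leave open how a chlorine or a methoxy group on the phenyl ring would read in this assay. They also leave open how a cyclobutyl or an isopropyl group on the ring nitrogen would compare.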